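Two Methoxy Groups on the Phenyl of a Weak Lead

The compounds below may be only part of what the source reports. "The series", "measured", "known", "first", "only" and "open" are said of these compounds alone.

Compound 1 `CC(=O)n1cc(/C=C(/C(=O)O)c2ccccc2)c2cc(OCc3ccccc3)ccc21`: 26700 nM
Compound 2 `COc1ccccc1/C(=C\c1cn(C(C)=O)c2ccc(OCc3ccccc3)cc12)C(=O)O`: 1010 nM
Compound 3 `COc1ccc(/C(=C\c2cn(C(C)=O)c3ccc(OCc4ccccc4)cc23)C(=O)O)cc1OC`: 1050 nM

All three share one core and were compared in a functional assay on DU-145 cells (Homo sapiens) for cytotoxicity, read by MTT assay, with a stated time of 72 h; a higher number here means a weaker inhibitor, a lower number a stronger inhibitor. Compound 1, which carries a plain phenyl on the double-bonded chain carbon, gives the highest number of the three and is thus the weakest of this set. Two changes to that phenyl have been measured: a 26-fold lower number from compound 1 to compound 2 (1.42 log units; beyond the scatter), and a 25-fold lower number from compound 1 to compound 3 (1.41 log units; beyond the scatter). Both steps are large and run the same way. The two methoxy-bearing compounds sit close together, as a 1.0-fold higher number from compound 2 to compound 3 (0.02 log units; within the scatter) shows.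

Compound 4 `COc1cc(OC)cc(/C(=C\c2cn(C(C)=O)c3ccc(OCc4ccccc4)cc23)C(=O)O)c1` has not yet been measured in this assay. It differs from compound 1 in one place: 3,5-dimethoxyphenyl in place of phenyl on a double-bonded chain carbon bound to a carbonyl carbon and a double-bonded chain carbon. Within the data shown here, since compound 3 showed that two methoxy groups on this phenyl bring the number down sharply, a similar drop is expected here, though the methoxy groups now sit at different positions of the ring and only two examples exist. The estimated step is an 18-fold lower number from compound 1 to compound 4 (1.25 log units; beyond the scatter). Compound 4 is therefore expected to give about 1500 nM in this assay, within a range of 500 nM to 6000 nM.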

Compound 4, half-maximal inhibitory concentration: 880 nM
The estimate for compound 4 lay 1.7-fold (0.23 log units) above the measured number; the range from low to high includes it.
By their numbers in this assay, from the lowest: compounds 4, 2 and 3 (each within the scatter of the next); then compound 1.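

In this assay the 3,5-dimethoxyphenyl group gives the same large drop from the plain phenyl as the earlier methoxy-bearing groups (a 30-fold lower number from compound 1 to compound 4 (1.48 log units; beyond the scatter)), so this drop now appears with three different methoxy patterns on the ring. Changing to this group from either earlier pattern moves the number by no more than the scatter (a 1.2-fold lower number from compound 3 to compound 4 (0.08 log units; within the scatter); a 1.1-fold lower number from compound 2 to compound 4 (0.06 log units; within the scatter)). Among compounds 2, 3 and 4, the number and placing of the methoxy groups therefore do not separate the results; only compound 1, without methoxy, stands apart. No measurement here explains this shared drop.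

From the compounds shown here alone, it remains open whether methoxy itself is needed, or whether a hydroxyl, a chlorine or an amine on the same phenyl would lower the number as far.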